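Flipping the double bond of compound 2

The source may hold more compounds than are shown below. What is called first, only, known or untested is meant among the compounds shown, and "the series" means these compounds.

Compound 2 `CC/C(=C(\c1ccccc1)c1ccc(NC(=O)C(C)C)cc1)c1ccc(OCc2ccccc2)cc1` is one of a small set of triarylethenes bearing an isobutyramide. In a functional assay on MCF7 cells (Homo sapiens) for inhibition, read by trypan blue exclusion, with a stated time of 72 h (on this read-out higher numbers stand for weaker inhibition of growth and lower numbers for stronger inhibition of growth), compound 2 gives only a limit, > 30000 nM. Compound 1 `CC/C(=C(\c1ccccc1)c1ccc(NC(=O)C(C)C)cc1)c1ccccc1` likewise reaches only a limit in this assay, > 30000 nM. Compound 3 `CC/C(=C(/c1ccc(NC(=O)C(C)C)cc1)c1ccc(OC)cc1)c1ccc(OCc2ccccc2)cc1` gives 29000 nM in this assay. The step that the two limits leave unreadable from compound 1 to compound 2 cannot be read, and the step of an at least 1.0-fold lower number from compound 2 to compound 3 (0.01 log units; that floor lies within the scatter) sits within the scatter, so that the limit of > 30000 nM in this assay, at which 2 of the 3 values shown sit, dominates the picture. Compound 4 `CC/C(=C(/c1ccccc1)c1ccc(NC(=O)C(C)C)cc1)c1ccc(OCc2ccccc2)cc1` differs from compound 2 only in configuration: the two compounds have the same atoms and bonds and differ only in configuration as drawn: 1 of 1 stereo elements differ; a double bond is drawn Z in compound 2 and E in compound 4. Among the measured compounds shown here, no measured step covers such a change, so the expected step of a number no higher from compound 2 to compound 4 (the limit leaves the size open) is uncertain but tilted toward a limit. Compound 4 is therefore estimated at 30000 nM, within 5000 nM to 60000 nM.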

Compound 4, concentration for 50% growth inhibition: > 30000 nM
Compound 4 was reported as a limit (the forecaster's own chance of this, stated with the estimate: 60%); the middle value sits exactly at the limit.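

In this assay, among the compounds shown here, compound 4 gives only a limit, > 30000 nM, and compound 2 is also known only as a limit, so no step between them can be read. The compounds shown leave open whether the configuration of the double bond alters growth inhibition at all.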